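Bromo to carboxy on the aromatic ring

A few compounds are considered here, and "the series" means these few. Any claim that something is new, unique, unknown or untested is made for them only; others in the source may bear on it.

Values from a functional assay on A549 cells (Homo sapiens) for cytotoxicity, read by MTT assay, with a stated time of 48 h (a higher number here means a weaker inhibitor, a lower number a stronger inhibitor), for the measured compounds:
- compound 1 `CC1(C)CCC[C@]2(C)[C@@H](CC[C@@](C)(O)/C=C/c3cccc([N+](=O)[O-])c3)[C@](C)(O)CC[C@@H]12` gives 3400 nM
- compound 2 `Cc1cccc(/C=C/[C@](C)(O)CC[C@@H]2[C@@]3(C)CCCC(C)(C)[C@@H]3CC[C@@]2(C)O)c1C` gives 3800 nM
- compound 3 `CC1(C)CCC[C@]2(C)[C@@H](CC[C@@](C)(O)/C=C/c3ccc(Br)cc3)[C@](C)(O)CC[C@@H]12` gives 43200 nM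

Compound 3 has the highest number of the three, beyond the scatter against both others. Compound 4 `CC1(C)CCC[C@]2(C)[C@@H](CC[C@@](C)(O)/C=C/c3ccc(C(=O)O)cc3)[C@](C)(O)CC[C@@H]12` differs from it in one place, with carboxy in place of bromo on an aromatic carbon. Within the data shown here, no measured step involves a carboxy group. The nearest evidence is other aryl swaps: a 13-fold higher number from compound 1 to compound 3 (1.10 log units; beyond the scatter) was large, as was an 11-fold higher number from compound 2 to compound 3 (1.06 log units; beyond the scatter) while a 1.1-fold higher number from compound 1 to compound 2 (0.05 log units; within the scatter) stayed within the scatter. Swaps here can therefore shift this assay widely. With compound 3 at the top, a lower number is expected, as a 2.9-fold lower number from compound 3 to compound 4 (0.46 log units; beyond the scatter) with wide uncertainty. Compound 4 is estimated at 15000 nM with an expected range of 4000 nM to 60000 nM in this measurement.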

Compound 4, half-maximal inhibitory concentration: 44300 nM
Compound 4: middle estimate off by 3.0-fold (0.47 log units), on the low side; the range from low to high includes it.
By their numbers in this assay, from the lowest: compounds 1 and 2 (each within the scatter of the next); then compounds 3 and 4 (each within the scatter of the next).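

In this assay, carboxy on this aromatic carbon, para to a large group, reads the same as bromo, with a 1.0-fold higher number from compound 3 to compound 4 (0.01 log units; within the scatter). The large gaps to the other aryl compounds therefore persist, with a 12-fold higher number from compound 2 to compound 4 (1.07 log units; beyond the scatter) and a 13-fold higher number from compound 1 to compound 4 (1.11 log units; beyond the scatter), so the 4-carboxyphenyl compound sits with the 4-bromophenyl one. No evidence available here explains why these two groups give matching numbers.

As far as these compounds go, whether the high number belongs to this position or only to these two groups remains open. An amine or a methoxy group on the same carbon would test that.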